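Methyl added to the aromatic ring of compound 3

The compounds below may be only part of what the source reports. "The series", "measured", "known", "first", "only" and "open" are said of these compounds alone.

Compound 3 `N/C(=N\NC(=S)N1CCCC1)c1ccccn1` gives 6200 nM in a functional assay on HeLa cells (Homo sapiens) for cytotoxicity, read by MTT assay, with a stated time of 72 h (a lower number here means a stronger inhibitor, a higher number a weaker inhibitor), and stands lowest of the three measured numbers. Compound 2 `Cc1ccnc(/C(N)=N/NC(=S)N2CCSCC2)c1` gives 15500 nM in this assay, and compound 1 `Cc1ccnc(/C(N)=N/NC(=S)N2CCOCC2)c1` gives 38500 nM. Among the measured compounds shown here, the only measured step, a 2.5-fold lower number from compound 1 to compound 2 (0.40 log units; beyond the scatter), concerns the group on the thiocarbonyl carbon, not the aromatic ring. Compound 4 `Cc1ccnc(/C(N)=N/NC(=S)N2CCCC2)c1` differs from compound 3 by methyl in place of hydrogen on an aromatic carbon. For the measured compounds named here, no measured step isolates this change: compounds 1 and 2 carry the methyl and compound 3 does not, but they also differ at the thiocarbonyl carbon. The step from compound 3 to compound 4 in this assay is therefore expected to stay within the scatter, a 1.0-fold higher number from compound 3 to compound 4 (0.02 log units; within the scatter). Compound 4 is estimated at 6500 nM, with a range of 2500 nM to 17000 nM.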

Compound 4, half-maximal inhibitory concentration: 1900 nM
Compound 4: middle estimate off by 3.4-fold (0.53 log units), on the high side; measured number below the stated range.
By their numbers in this assay, from the lowest: compound 4; then compound 3; then compound 2; then compound 1.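

In this assay, among the compounds shown here, methyl in place of hydrogen on the aromatic carbon opposite the ring nitrogen gives a 3.3-fold lower number from compound 3 to compound 4 (0.51 log units; beyond the scatter), the first reading that isolates this position. With the methyl held constant, the group on the thiocarbonyl carbon also matters: pyrrolidin-1-yl in place of thiomorpholin-4-yl gives an 8.2-fold lower number from compound 2 to compound 4 (0.91 log units; beyond the scatter), and pyrrolidin-1-yl in place of morpholin-4-yl gives a 20-fold lower number from compound 1 to compound 4 (1.31 log units; beyond the scatter). No measured evidence accounts for these steps. From the compounds shown here alone, whether ethyl, methoxy or chlorine on this same carbon would match the methyl remains open. Also open, going by these compounds, is whether the methyl step carries over to the morpholin-4-yl and thiomorpholin-4-yl compounds.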